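A Second Methoxy Group Added to Compound 2

A few compounds are considered here, and "the series" means these few. Any claim that something is new, unique, unknown or untested is made for them only; others in the source may bear on it.

Of the compounds shown here, two have so far been tested in a functional assay on WI-38 VA13 cells (Homo sapiens) for cytotoxicity; a lower number here means that less compound is needed, a higher number that more compound is needed for the effect. Compound 1 `CCOC(=O)c1sc2nc(-c3cccs3)ccc2c1N` gives > 4 ug/mL there, which is a limit of the assay rather than a number; it sits at the limit of > 4 ug/mL in this assay, at which 1 of the 2 values shown sits. Among the measured compounds shown here, compound 2 `COc1ccccc1C(=O)c1oc2cc(-c3ccccc3)cc(O)c2c1C` gives 0.09 ug/mL in this assay, the only genuine number among the two results. Compound 3 `COc1ccc(OC)c(C(=O)c2oc3cc(-c4ccccc4)cc(O)c3c2C)c1` is a variant of compound 2, differing by methoxy in place of hydrogen on an aromatic carbon. For the measured compounds named here, no step between two measured compounds is available to guide the prediction, so the expected change rests on the change itself, which is a small addition on an outer ring. The step of a 1.1-fold higher number from compound 2 to compound 3 (0.05 log units; within the scatter) is expected to stay within the usual scatter, in no particular direction. Compound 3 is therefore estimated at 0.1 ug/mL, with a range from 0.04 ug/mL to 0.3 ug/mL.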

Compound 3, half-maximal effective concentration: 0.09 ug/mL
Compound 3: the middle estimate sits 1.1-fold (0.05 log units) above what was measured; measured number inside the range.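

In this assay, putting a methoxy group in place of hydrogen gives no change at the digits printed from compound 2 to compound 3 (within the scatter). The carbon concerned lies on a six-membered aromatic ring of carbon only, meta to a large group and para to a methoxy group, and at this place the added group leaves no difference that can be told from scatter. This is the only pair shown that differs in one place, so it gives the only direct reading of a change on this ring, and no measurement shown explains the result.

A single group at a single position cannot show how far this holds. On these data alone, an amine, a carboxylic acid or a longer chain on the same carbon might give a different number, and the role of the methoxy group already present in compound 2 remains open.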